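The source may hold more compounds than are shown below. What is called first, only, known or untested is meant among the compounds shown, and "the series" means these compounds.

Measured in a functional assay on DU-145 cells (Homo sapiens) for inhibition, read by trypan blue exclusion, with a stated time of 72 h; on this read-out lower numbers stand for stronger inhibition and higher numbers for weaker inhibition:

- compound 1 `COC(=O)Cn1c(=O)c(S(=O)(=O)c2ccc(F)cc2F)cc2cnc(Nc3ccc4[nH]ccc4c3)nc21` gives 10000 nM
- compound 2 `Cn1c(=O)c(S(=O)(=O)c2ccc(Cl)cc2Cl)cc2cnc(Nc3ccc4[nH]ccc4c3)nc21` gives 1000 nM
- compound 3 `Cc1ccc(S(=O)(=O)c2cc3cnc(Nc4ccc5cc[nH]c5c4)nc3n(C)c2=O)cc1` gives 15000 nM

Compound 2 stands lowest of the three numbers. Compound 1 lies at a higher number, and compound 3 at a higher one still; both gaps to compound 2 are beyond the usual scatter, so compound 2 is the strongest inhibitor shown here. Within the data shown here, no pair of measured compounds differs in only one place, so no single step can be read off.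

Compound 4 `Cn1c(=O)c(S(=O)(=O)c2ccc(Br)cc2)cc2cnc(Nc3ccc4[nH]ccc4c3)nc21` has not yet been run in this assay. Against compound 2 the change is 4-bromophenyl in place of 2,4-dichlorophenyl on a sulfonyl sulfur: the (2,4-dichlorophenyl)sulfonyl of compound 2 becomes (4-bromophenyl)sulfonyl, one chlorine fewer on that ring. Among the measured set, compound 3 carries a single group on the phenyl at its sulfonyl sulfur and gives 15000 nM, while the two-halogen compound 2 sits much lower, so a move to a single halogen is expected to cost potency. The step from compound 2 to compound 4 is expected to be a 4.0-fold higher number from compound 2 to compound 4 (0.60 log units; beyond the scatter), a rise beyond the scatter. Compound 4 is therefore estimated at 4000 nM, with a range from 1500 nM to 12000 nM.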

Compound 4, half-maximal inhibitory concentration: 5000 nM
The estimate for compound 4 lay 1.3-fold (0.10 log units) below the measured number; low and high end bracket the measured number.
By their numbers in this assay, from the lowest: compound 2; then compounds 4, 1 and 3 (each within the scatter of the next, the first and the last beyond it).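

Among these compounds, this is the first single-place reading: in this assay the aryl group on the sulfonyl sulfur is changed alone and gives a 5.0-fold higher number from compound 2 to compound 4 (0.70 log units; beyond the scatter) with the rest of the structure held constant. The group on the sulfonyl sulfur therefore affects the read-out on its own, although the step is modest. The change combines loss of a chlorine with replacement of the remaining halogen by bromine, so the two parts cannot be separated, and no measured evidence accounts for the step.

Open, as far as these compounds go, is whether the difference follows the number of halogens or the identity of the halogen, which a 4-chlorophenyl or unsubstituted phenyl group on the sulfonyl sulfur would help separate. Also open, from the compounds shown here alone, is how an aryl group carrying an amine or a carboxylic acid would read out at this position.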